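This account rests on a few compounds, and the source may have more. Where it says the series, first, only, none or still open, it means among the compounds named here.

In an assay on isolated protein for inhibition of Maltase-glucoamylase (Homo sapiens) (on this read-out lower numbers stand for stronger inhibition and higher numbers for weaker inhibition), compound 2 `C=C1CC[C@@H]2[C@](C)(COC(=O)c3cccnc3)[C@H](OC(=O)c3cccnc3)CC[C@@]2(C)[C@@H]1/C=C/C1=C/C(=C\c2ccccc2)OC1=O` gives 16000 nM, the lowest of the two numbers available. Within the data shown here, compound 1 `C=C1CC[C@@H]2[C@](C)(CO)[C@H](O)CC[C@@]2(C)[C@@H]1/C=C/C1=C/C(=C/c2ccccc2)OC1=O`, the only other measured compound, gives in this assay 58000 nM, a gap that lies beyond the usual scatter. Compound 3 `C=C1CC[C@@H]2[C@](C)(COC(=O)c3cccnc3)[C@H](OC(=O)c3cccnc3)CC[C@@]2(C)[C@@H]1/C=C/C1=C/C(=C\c2ccc(Cl)cc2)OC1=O` differs from compound 2 by one change: chloro in place of hydrogen on an aromatic carbon. Among the measured compounds shown here, no measured pair shows this change, so its effect is unknown from these data. The expected step in this assay is a 1.3-fold lower number from compound 2 to compound 3 (0.12 log units; within the scatter), none beyond the scatter. Compound 3 is therefore estimated to give 12000 nM, with a range from 5000 nM to 30000 nM.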

Compound 3, half-maximal inhibitory concentration: 6000 nM
Compound 3: middle estimate off by 2.0-fold (0.30 log units), on the high side; low and high end bracket the measured number.
By their numbers in this assay, from the lowest: compound 3; then compound 2; then compound 1.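

In this assay, the change from phenyl to 4-chlorophenyl gives a 2.7-fold lower number from compound 2 to compound 3 (0.43 log units; beyond the scatter) and so shows that this place on the aromatic ring, para to a large group, takes a chloro with a modest gain. Among these compounds, it is the first step read at this ring, and the first single change read. Nothing available gives a reason for the shift. Open, as far as these compounds go, is whether a bromo, a methoxy or an amine at the same place would do the same, and whether chloro would bring a similar step on compound 1.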